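The source may hold more compounds than are shown below. What is called first, only, known or untested is meant among the compounds shown, and "the series" means these compounds.

Compound 1 `O=S(=O)(c1ccccc1Cl)c1cn(C2CCCNC2)c2ncccc12`: 84%
Compound 2 `CN1CCCC(n2cc(S(=O)(=O)c3cccc(F)c3)c3cccnc32)C1`: 75%

In a functional assay on HeLa cells for agonist activity at 5-hydroxytryptamine receptor 6 (Homo sapiens), read by cAMP accumulation and immunoassay (on this read-out higher numbers stand for larger maximal responses and lower numbers for smaller maximal responses), compound 1 holds the higher of the two numbers, yet compound 2 sits within the scatter of it, so the two cannot be ordered. Compound 3 `O=S(=O)(C1=C(Cl)NC2SC=CN12)c1cn(C2CCCNC2)c2ncccc12` is not yet measured; it differs from compound 1 as follows: a group of 9 heavy atoms (5 carbon, 2 nitrogen, 1 sulfur, 1 chlorine; 2 five-membered non-aromatic rings with 2 hetero atoms each) in place of a group of 7 heavy atoms (6 carbon, 1 chlorine; one six-membered aromatic ring of carbon only), on a sulfonyl sulfur. Among the compounds with values here, no measured pair shows a change of this kind, so nothing tells how this assay answers it. The step of a number 9 percentage points lower from compound 1 to compound 3 (within the scatter) is therefore expected to be small, with no direction beyond the scatter. For compound 3 the estimate is 75%, between 50% and 95%.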

Compound 3, largest response reached (Emax), in percent of the reference or control that the assay uses: 47%
Compound 3: middle estimate off by 28 percentage points, on the high side, and the stated range ends above it.
By their numbers in this assay, from the lowest: compound 3; then compounds 2 and 1 (each within the scatter of the next).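

In this assay the swap of 2-chlorophenyl on the sulfonyl sulfur for the group with two five-membered non-aromatic rings gives a number 37 percentage points lower from compound 1 to compound 3 (beyond the scatter), so the maximal response depends on what sits at this place. Compound 1 and compound 2 differ in more than one place and could not show this. Nothing measured here accounts for the drop. As far as these compounds go, it remains open whether the whole two-ring group or only part of it matters, and how an unsubstituted phenyl or a pyridine would answer on the sulfonyl sulfur.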